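The source may hold more compounds than are shown below. What is called first, only, known or untested is meant among the compounds shown, and "the series" means these compounds.

Working notes on the series. In a functional assay on Z-138 cells (Homo sapiens) for inhibition, read by luminescence and CellTiter-Glo, with a stated time of 72 h (a lower number here means a stronger inhibitor, a higher number a weaker inhibitor), compound 1 `O=C(CCl)N1CCCC(n2nc(-c3ccc(Oc4ccccc4)cc3)cc2CO)C1` gives 400 nM, the lower of the two numeric values, and compound 3 `CCOC(=O)c1cc(-c2ccc(Oc3ccccc3)cc2)nn1C1CCCN(C(=O)CCl)C1` gives 1300 nM. Compound 2 `C/C=C/C(=O)Nc1ccc(Cn2nc(-c3ccc(Oc4ccccc4)cc3)cc2C(=O)OCC)cc1` reads > 60000 nM, which is a limit and not a number.

The next candidate is compound 4 `C=CC(=O)N1CCCC(n2nc(-c3ccc(Oc4ccccc4)cc3)cc2CO)C1`, which differs from compound 1 as follows: vinyl in place of chloromethyl on a carbonyl carbon. In words, it has vinyl in place of chloromethyl on a carbonyl carbon.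

Among the measured compounds shown here, only one measured step connects compounds that differ in a single place: a 3.3-fold higher number from compound 1 to compound 3 (0.51 log units; beyond the scatter), with ethoxycarbonyl in place of hydroxymethyl on an aromatic carbon. That step lies at another site, so it gives a scale and not a direct precedent. For the measured compounds named here, no measured pair compares vinyl with chloromethyl on the carbonyl carbon. Compound 2 has no chloromethyl but differs from compound 1 in several other places. Compound 2 has a limit of > 60000 nM that only tilts the expectation towards a higher number.

In this assay, the expected change is therefore modest, and the estimated step is a 3.0-fold higher number from compound 1 to compound 4 (0.48 log units; beyond the scatter). For compound 4 the estimated value is 1200 nM, with an expected range of 250 nM to 6000 nM.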

Compound 4, half-maximal inhibitory concentration: 14600 nM
Compound 4: the middle estimate sits 12-fold (1.09 log units) below what was measured, outside the stated range (above it).
By their numbers in this assay, from the lowest: compound 1; then compound 3; then compound 4. At a limit, above all of these: compound 2.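

In this assay, the group on the carbonyl carbon is the first site shown to move the number by a large margin: vinyl in place of chloromethyl gives a 37-fold higher number from compound 1 to compound 4 (1.56 log units; beyond the scatter) with the rest of the core of compound 1 unchanged. Of the two single-place changes shown, this one is clearly the larger, since ethoxycarbonyl in place of hydroxymethyl on an aromatic carbon gives only a 3.3-fold higher number from compound 1 to compound 3 (0.51 log units; beyond the scatter) and so the carbonyl substituent, more than that aromatic substituent, sets the reading among these compounds. Nothing measured on these compounds accounts for the size of the step, so the result records the swap of chloromethyl for vinyl, with its loss of chlorine and gain of a double bond, and gives no reason for it.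

Open, from the compounds shown here alone, is whether the same swap costs as much when ethoxycarbonyl stands on the aromatic carbon, as it does in compound 3, in place of hydroxymethyl. Also open, going by these compounds, is how a plain methyl, a bromomethyl or a dimethylaminomethyl-bearing vinyl on the carbonyl carbon would read, which would show whether the chlorine itself or the chloromethyl group as a whole carries the lower number of compound 1.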